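The compounds below may be only part of what the source reports. "The series", "measured", "known", "first", "only" and "open" are said of these compounds alone.

Measured compounds:
Compound 1, `Cc1ccc(-c2c3ccc4ccccc4c3nc3c2c(C)nc2c4ccccc4ccc32)cc1`, gives 192 ug/mL in a functional assay, with a stated time of 90 s; on this read-out higher numbers stand for weaker inhibition and lower numbers for stronger inhibition.
Compound 2, `Cc1nc2c3ccccc3ccc2c2nc3c(ccc4ccccc43)c(-c3ccccc3)c12`, gives 188 ug/mL in this assay.
Compound 3, `Cc1nc2c3ccccc3ccc2c2nc3c(ccc4ccccc43)c(-c3nccnc3N)c12`, gives 134 ug/mL in this assay.

Compound 3 has the lowest of the three numbers, but its gaps to the others are small: a 1.4-fold lower number from compound 1 to compound 3 (0.16 log units; within the scatter) and a 1.4-fold lower number from compound 2 to compound 3 (0.15 log units; within the scatter), so the three compounds cannot be told apart on these data.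

Compound 4, `COc1ccc(-c2c3ccc4ccccc4c3nc3c2c(C)nc2c4ccccc4ccc32)cc1`, is the next compound. Its difference from compound 3 is 4-methoxyphenyl in place of 3-aminopyrazin-2-yl on an aromatic carbon. For the measured compounds named here, the steps that bear on this are the two just named, in which an aryl group was replaced by 3-aminopyrazin-2-yl and the number moved only within the scatter. Here the change runs the other way, back to an aryl group, and 4-methoxyphenyl is close to the 4-methylphenyl of compound 1. A small rise, if any, is therefore expected in this assay, as a 1.3-fold higher number from compound 3 to compound 4 (0.13 log units; within the scatter), staying within the scatter. Compound 4 is estimated at 180 ug/mL, with a range from 110 ug/mL to 300 ug/mL.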

Compound 4, half-maximal inhibitory concentration: 176 ug/mL
Beside the measured number, compound 4's estimate is 1.0-fold (0.01 log units) above it; low and high end bracket the measured number.
By their numbers in this assay, from the lowest: compounds 3, 4, 2 and 1 (each within the scatter of the next).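

In this assay, putting 4-methoxyphenyl in place of 3-aminopyrazin-2-yl gives a 1.3-fold higher number from compound 3 to compound 4 (0.12 log units; within the scatter), so at this position a ring of carbon only and a ring with 2 hetero atoms cannot be told apart, even though the hydrogen-bond donor is lost. Methoxy on the phenyl ring reads the same as hydrogen, a 1.1-fold lower number from compound 2 to compound 4 (0.03 log units; within the scatter), and the same as methyl, a 1.1-fold lower number from compound 1 to compound 4 (0.04 log units; within the scatter), so these three cannot be told apart either. Nothing available speaks to why the numbers stay so close.

Every group shown at this position is a six-membered aromatic ring, so it remains open whether an amine, a carboxylic acid or a longer alkyl chain placed there would move the number beyond the scatter. Also open, as far as these compounds go, is whether changing the methyl group on the shared core would matter.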